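A few compounds are considered here, and "the series" means these few. Any claim that something is new, unique, unknown or untested is made for them only; others in the source may bear on it.

Measured compounds and values:
- compound 1, `COc1ccc(Nc2nnc(Nc3nc(-c4ccc(Br)cc4)cs3)s2)cc1`, in a functional assay on the whole organism (strain albino) with Mus musculus as the target, in the maximal electroshock model; a higher number here means that more compound is needed for the effect, a lower number that less compound is needed: 27.6 mg/kg
- compound 2, `Cc1ccc(Nc2nnc(Nc3nc(-c4ccc([N+](=O)[O-])cc4)cs3)s2)cc1`, in this assay: 19.1 mg/kg

Compound 2 holds the lowest of the two numbers, but its nearest neighbour, compound 1, sits only a little higher and the gap between them is within the scatter, so neither can be called the more potent. Within the data shown here, no step between compounds that differ in a single place is available; the two measured compounds differ from each other in two places at once, so their values alone tell nothing about either change separately.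

Compound 3, `COc1ccc(Nc2nnc(Nc3nc(-c4ccc([N+](=O)[O-])cc4)cs3)s2)cc1`, is the next member to be measured in this assay. It differs from compound 2 by methoxy in place of methyl on an aromatic carbon, para to a large group. The pair of measured values gives no basis for a directed step, and the change is small in what is counted. The expected step from compound 2 to compound 3 is a 1.0-fold higher number from compound 2 to compound 3 (0.02 log units; within the scatter), none beyond the scatter. Compound 3 is therefore estimated at 20 mg/kg, within a range from 10 mg/kg to 40 mg/kg.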

Compound 3, dose for half-maximal effect: 12.6 mg/kg
Estimate against measurement, compound 3: 1.6-fold (0.20 log units) above; the measured number falls inside the stated range.
By their numbers in this assay, from the lowest: compounds 3, 2 and 1 (each within the scatter of the next, the first and the last beyond it).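

In this assay, the series now has its first steps that change a single place. Methoxy in place of methyl on an aromatic carbon, para to a large group, gives a 1.5-fold lower number from compound 2 to compound 3 (0.18 log units; within the scatter), so the 4-methylphenyl and 4-methoxyphenyl members cannot be told apart here, even though methoxy adds one heavy atom and one hydrogen-bond acceptor. Nitro in place of bromo on an aromatic carbon, with the 4-methoxyphenyl group held constant, gives a 2.2-fold lower number from compound 1 to compound 3 (0.34 log units; beyond the scatter), a modest step and the only one so far that clears the scatter. Nothing at hand accounts for the size of either step.

Still open, on these data alone, is whether methyl and methoxy stay this close with a group other than nitro on the far aromatic ring, and whether the step from bromo to nitro carries over to the 4-methylphenyl series. Also open, as far as these compounds go, is how the series responds to a different kind of group at either place, such as an amine, a carboxylic acid or a longer alkoxy chain.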